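Working notes: sulfonyl substituent exchange from compound 1 to compound 4

The source may hold more compounds than are shown below. What is called first, only, known or untested is meant among the compounds shown, and "the series" means these compounds.

Measured in a functional assay on the whole organism (trachea) with Rattus norvegicus as the target; a higher number here means a larger maximal response, a lower number a smaller maximal response:
compound 1 `CC(C)NS(=O)(=O)c1ccc2c(c1)C(n1ccccc1=O)=CC(C)(C)O2` gives 94.8%
compound 2 `CC1(C)C=C(n2ccccc2=O)c2cc(S(=O)(=O)NCc3ccccc3)ccc2O1` gives 77.5%
compound 3 `CC1(C)C=C(n2ccccc2=O)c2cc(S(=O)(=O)Nc3ccccc3)ccc2O1` gives 7.85%; 88% (2 entries)

Compound 1 stands highest of the two single numbers; the nearest is compound 2, with the step of a number 17.3 percentage points lower from compound 1 to compound 2 (beyond the scatter), a modest fall beyond the scatter. Compound 3 carries no single number, since the several entries of compound 3 in this assay, 7.85%; 88% (2 entries) lie far apart. Compound 4 `CC1(C)C=C(n2ccccc2=O)c2cc(S(=O)(=O)Oc3ccccc3)ccc2O1` differs from compound 1 by phenoxy in place of isopropylamino on a sulfonyl sulfur. For the measured compounds named here, only the step from compound 1 to compound 2 bears on it, a modest drop when the sulfonamide nitrogen carries a larger group; compound 3 gives no usable direction. A downward step of similar size is expected, a number 22.8 percentage points lower from compound 1 to compound 4 (beyond the scatter). Compound 4 is estimated at 72%, within 25% to 100%.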

Compound 4, largest response reached (Emax), in percent of the reference or control that the assay uses: 86.7%
Compound 4: middle estimate off by 14.7 percentage points, on the low side; the range from low to high includes it.
By their numbers in this assay, from the lowest: compounds 2, 4 and 1 (each within the scatter of the next, the first and the last beyond it).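

In this assay the sulfonyl sulfur takes phenoxy in place of isopropylamino (a number 8.1 percentage points lower from compound 1 to compound 4 (within the scatter)) and in place of benzylamino (a number 9.2 percentage points higher from compound 2 to compound 4 (within the scatter)). Compound 4 thus shows that the sulfonamide nitrogen, with its hydrogen-bond donor, can give way to an oxygen link while the maximal response stays within the scatter of both compound 1 and compound 2.

Going by these compounds, whether methoxy or morpholine on the sulfonyl sulfur would hold the response stays open. The direct comparison of phenoxy with phenylamino also cannot be read: the several entries of compound 3 in this assay, 7.85%; 88% (2 entries)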